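Working notes: from compound 2 to compound 4

The compounds below may be only part of what the source reports. "The series", "measured", "known", "first", "only" and "open" are said of these compounds alone.

Measured compounds:
- compound 1 `Cc1ccccc1CN1CC=C(CCC(=O)NO)C1=O` gives 4620 nM
- compound 2 `O=C(CCC1=CCN(CCCc2ccc(Br)cc2)C1=O)NO` gives 3480 nM
- compound 3 `Cc1cccc(CN2CC=C(CCC(=O)NO)C2=O)c1` gives 4620 nM

All three numbers come from a functional assay on PC-3 cells (Homo sapiens) for inhibition, read by sulforhodamine B assay (on this read-out higher numbers stand for weaker inhibition of growth and lower numbers for stronger inhibition of growth), and sit close together. Compound 2 gives the lowest of the three numbers, but the gap to compound 1 and the gap to compound 3 both lie within the usual scatter, so the three compounds are not told apart by this assay.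

Compound 4 `CCOc1ccc(CCCN2CC=C(CCC(=O)NO)C2=O)cc1` differs from compound 2 in one place: ethoxy in place of bromo on an aromatic carbon. Going by the values given here, no pair of measured compounds differs in exactly one place, so there is no measured step to lean on for this exchange, and none of the measured compounds carries an ethoxy on the aromatic ring. The expectation therefore rests on the narrow spread of the three measured values alone. The step of a 1.0-fold higher number from compound 2 to compound 4 (0.01 log units; within the scatter) is expected to be small, without a set direction, and not beyond the scatter. For compound 4 in this assay the estimate is 3600 nM, with a range from 1500 nM to 8500 nM.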

Compound 4, concentration for 50% growth inhibition: 3480 nM
Compound 4: the middle estimate sits 1.0-fold (0.01 log units) above what was measured; low and high end bracket the measured number.
By their numbers in this assay, from the lowest: compounds 2, 4, 1 and 3 (each within the scatter of the next).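

In this assay, going by these compounds alone, the only one-place exchange, ethoxy in place of bromo, gives no change at the digits printed from compound 2 to compound 4 (within the scatter) and supplies the first direct reading at this position. The aromatic carbon para to a large group therefore accepts ethoxy, with 3 heavy atoms and 1 hydrogen-bond acceptor, in place of bromo, with 1 heavy atom and no hydrogen-bond acceptor, and the number does not move beyond the scatter. Nothing at hand explains why these two groups read alike.

Going by these compounds, whether an amine, a carboxylic acid or a longer alkoxy chain on the same aromatic carbon would also stay within the scatter remains open. Also open, on these data alone, is whether any group at this position can move the number beyond the scatter.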